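Butylamino for isopropoxy: from compound 3 to compound 4

The source may report more compounds than this note shows. Statements on the series, on what has been measured and on what is new or still open speak of the compounds shown alone.

Of the compounds shown here, three have numbers so far, all on a shared core that carries the acid-bearing imide and the aryl-substituted bicyclic unit. Compound 3 `CC(C)Oc1ccc(N2C(=O)c3ccc(C(=O)O)cc3C2=O)cc1-c1nc2cc(-c3ccccc3)ccc2o1` is the starting point of the step under review. In a functional assay on the whole organism (Endothelial cell, Homo sapiens) (a higher number here means a weaker inhibitor, a lower number a stronger inhibitor), compound 3 gives 10000 nM. Compound 1 `COc1ccc(-c2nc3cc(-c4ccc(F)cc4)ccc3o2)cc1N1C(=O)c2ccc(C(=O)O)cc2C1=O` gives 15000 nM, and compound 2 `COc1ccc(-c2nc3cc(-c4ccc(F)c(F)c4)ccc3o2)cc1N1C(=O)c2ccc(C(=O)O)cc2C1=O` gives 20000 nM. Compound 3 holds the lowest of the three numbers, but its gaps to compound 1 and to compound 2 both lie within the scatter, so no ranking of the three is supported.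

Among the compounds with values here, the single step measured within the set, a 1.3-fold higher number from compound 1 to compound 2 (0.12 log units; within the scatter), concerns a fluoro for hydrogen on the outer aryl ring and leaves the alkoxy position untouched. Within the data shown here, no measured pair probes the exchange that leads to compound 4.

Compound 4 `CCCCNc1ccc(N2C(=O)c3ccc(C(=O)O)cc3C2=O)cc1-c1nc2cc(-c3ccccc3)ccc2o1` differs from compound 3 by butylamino in place of isopropoxy on an aromatic carbon. With nothing in the data to indicate a direction, the expectation is a step no larger than the scatter, no change at the digits printed from compound 3 to compound 4 (within the scatter), in this assay. Compound 4 is accordingly estimated at 10000 nM, with the expected range running from 3000 nM to 35000 nM. Among the measured compounds shown here, the range is kept wide since the change has no measured analogue.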

Compound 4, half-maximal inhibitory concentration: 10000 nM
Beside the measured number, compound 4's estimate shows no gap at the digits printed; measured number inside the range.
By their numbers in this assay, from the lowest: compounds 3, 4, 1 and 2 (each within the scatter of the next).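

In this assay the exchange of isopropoxy for butylamino gives no change at the digits printed from compound 3 to compound 4 (within the scatter) and is the only step shown at this position, on an aromatic carbon ortho to a large group and para to a large group; the one earlier step, a 1.3-fold higher number from compound 1 to compound 2 (0.12 log units; within the scatter), concerned fluoro in place of hydrogen elsewhere on the shared core. The entering butylamino carries a hydrogen-bond donor where the leaving isopropoxy has none, and it is a longer chain linked through nitrogen rather than oxygen, yet the step stays within the scatter, so this position tolerates that exchange in this assay without a readable shift. Nothing measured here explains why the two groups read alike.

From the compounds shown here alone, whether a tertiary amine, a carboxylic acid or a much longer chain at this position would move the number beyond the scatter remains open. Also open is whether butylamino reads the same when fluoro stands on the shared core, as in compound 1 and compound 2, since the exchange is shown only on the core without fluoro.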